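The source may hold more compounds than are shown below. What is called first, only, known or untested is meant among the compounds shown, and "the series" means these compounds.

Measured compounds: compound 1 `CS(=O)(=O)c1cc(F)ccc1NCC1=NCCN1` gives 1620 nM; compound 2 `CSc1cc(F)ccc1NCC1=NCCN1` gives 5.01 nM; compound 3 `CSc1c(F)cccc1NCC1=NCCN1` gives 302 nM, all in an assay for binding affinity to Alpha-1D adrenergic receptor (Homo sapiens), read by radioligand binding; on this read-out lower numbers stand for stronger inhibition and higher numbers for weaker inhibition.

Compound 2 and compound 3 share the same atoms joined differently; the difference between the two cores is not broken down here. Compound 1 is obtained from compound 2 by the change (methylsulfonyl in place of methylsulfanyl on an aromatic carbon), and in this assay this gave a 320-fold higher number from compound 2 to compound 1 (2.51 log units; beyond the scatter). Compound 4 `CS(=O)(=O)c1c(F)cccc1NCC1=NCCN1` is not yet measured; it arises from compound 3 by methylsulfonyl in place of methylsulfanyl on an aromatic carbon, the same kind of change, though here the place is ortho to a fluoro group whereas in compound 1 it is meta to a fluoro group. Resting on the single earlier step, compound 4 is expected to show a large loss, estimated as a 99-fold higher number from compound 3 to compound 4 (2.00 log units; beyond the scatter). The value of compound 4 in this assay is expected to be about 30000 nM, between 5000 nM and 200000 nM.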

Compound 4, inhibition constant: 3470 nM
For compound 4 the middle estimate is 8.6-fold (0.94 log units) above the measured one; the measured number lies below the stated range.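

In this assay, methylsulfonyl in place of methylsulfanyl gives a higher number on both cores, here with an 11-fold higher number from compound 3 to compound 4 (1.06 log units; beyond the scatter), so the direction of the change carries over but its size does not: the same change on two cores in this assay, a 320-fold higher number (2.51 log units; beyond the scatter) from compound 2 to compound 1 and an 11-fold higher number (1.06 log units; beyond the scatter) from compound 3 to compound 4, 28-fold (1.45 log units) apart, beyond the scatter of two such steps

A large loss on one core therefore predicts a loss on the other in this pair of cores, but does not fix how large it will be. The two steps alone do not show why they differ, since the fluoro group's place cannot be separated from anything else about the cores.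

The compounds shown leave open how a methoxy group or a carboxylic acid would compare with methylsulfanyl on these cores. They also leave open how the change behaves with chlorine in place of the fluoro group.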